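A few compounds are considered here, and "the series" means these few. Any claim that something is new, unique, unknown or untested is made for them only; others in the source may bear on it.

Measured so far in a functional assay for antagonist activity at melanin-concentrating hormone receptor 1 (Homo sapiens); on this read-out higher numbers stand for weaker inhibition and lower numbers for stronger inhibition:
- compound 1, `N#Cc1cccc([C@]23CCC(N(CCN4CC[C@@H](O)C4)C(=O)Nc4cccc(Cl)c4)CC2C3)c1`, gives 27 nM
- compound 2, `N#Cc1cccc(NC(=O)N(CCN2CC[C@@H](O)C2)C2CC[C@]3(c4cccc(C#N)c4)CC3C2)c1`, gives 92 nM
- compound 3, `CC(C)N(CCN(C(=O)Nc1cccc(Cl)c1)C1CC[C@]2(c3cccc(C#N)c3)CC2C1)C(C)C`, gives 6 nM

Compound 2 differs from compound 1 in one place only: cyano in place of chloro on an aromatic carbon. That change gave a 3.4-fold higher number from compound 1 to compound 2 (0.53 log units; beyond the scatter), a weakening of inhibition that is modest but clear.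

Compound 3 carries a different core from compound 1. The difference between the two cores is diisopropylamino in place of 3-hydroxypyrrolidin-1-yl on a saturated chain carbon, two bonds along the chain from an amide-type nitrogen, and on its own it gave a 4.5-fold lower number from compound 1 to compound 3 (0.65 log units; beyond the scatter), so compound 3 shows the lowest number of the three measured compounds.

Compound 4, `CC(C)N(CCN(C(=O)Nc1cccc(C#N)c1)C1CC[C@]2(c3cccc(C#N)c3)CC2C1)C(C)C`, has not yet been measured. It differs from compound 3 by cyano in place of chloro on an aromatic carbon. The place of this change is described in the same words as for the earlier pair, so it is the same change, made on the core of compound 3 instead of the core of compound 1.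

Because a 3.4-fold higher number from compound 1 to compound 2 (0.53 log units; beyond the scatter) was seen on the other core, compound 4 is expected to show a similar weakening, a 3.3-fold higher number from compound 3 to compound 4 (0.52 log units; beyond the scatter). Compound 4 is therefore estimated at 20 nM, most likely between 8 nM and 50 nM.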

Compound 4, inhibition constant: 7.6 nM
For compound 4 the middle estimate is 2.6-fold (0.42 log units) above the measured one; measured number below the stated range.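

In this assay, cyano in place of chloro on the core of compound 3 gave a 1.3-fold higher number from compound 3 to compound 4 (0.10 log units; within the scatter), so the weakening seen on the core of compound 1 did not carry over at the same size: the same change on two cores in this assay, a 3.4-fold higher number (0.53 log units; beyond the scatter) from compound 1 to compound 2 and a 1.3-fold higher number (0.10 log units; within the scatter) from compound 3 to compound 4, 2.7-fold (0.43 log units) apart, beyond the scatter of two such steps

Read the other way, diisopropylamino in place of 3-hydroxypyrrolidin-1-yl gave a 12-fold lower number from compound 2 to compound 4 (1.08 log units; beyond the scatter), again a lower number but a step of a different size from the one on the chloro compounds: the same change on two cores in this assay, a 4.5-fold lower number (0.65 log units; beyond the scatter) from compound 1 to compound 3 and a 12-fold lower number (1.08 log units; beyond the scatter) from compound 2 to compound 4, 2.7-fold (0.43 log units) apart, beyond the scatter of two such steps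

These two comparisons come from the same four compounds, so they are one finding seen from two sides: the effect of each change depends on which group holds the other place, but nothing here shows why, or whether this holds beyond these compounds.

From the compounds shown here alone, it remains open whether the cyano step stays this small with other amines on the chain, such as dimethylamino or piperidine. Going by these compounds, it is also open how other groups on the same aromatic carbon, such as fluoro or methoxy, would behave on either core.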